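The compounds below may be only part of what the source reports. "The series", "measured", "known", "first", "only" and "open" are said of these compounds alone.

Measured so far:
Compound 1 `COc1cc2ncnc(Nc3ccc(Br)cc3)c2cc1OCCCCC(=O)Nc1ccc(S(N)(=O)=O)cc1` — 23300 nM
Compound 2 `COc1cc2ncnc(Nc3ccc(F)c(Br)c3)c2cc1OCCCCC(=O)Nc1ccc(S(N)(=O)=O)cc1` — 31600 nM
Compound 3 `COc1cc2ncnc(Nc3cccc(Cl)c3F)c2cc1OCCCCC(=O)Nc1ccc(S(N)(=O)=O)cc1` — 6930 nM

All three share the same core and differ only in the aryl group on the nitrogen attached to that core. In a functional assay on NCI-H1975 cells (Homo sapiens) for antiproliferative activity, read by MTT assay, with a stated time of 72 h (on this read-out higher numbers stand for weaker inhibition and lower numbers for stronger inhibition), compound 3 gives 6930 nM, the lowest number of the three; the nearest is compound 1 at 23300 nM, and compound 2 lies furthest at 31600 nM. The steps among them were modest: a 1.4-fold higher number from compound 1 to compound 2 (0.13 log units; within the scatter), a 3.4-fold lower number from compound 1 to compound 3 (0.53 log units; beyond the scatter), and a 4.6-fold lower number from compound 2 to compound 3 (0.66 log units; beyond the scatter).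

Compound 4 `COc1ccccc1Nc1ncnc2cc(OC)c(OCCCCC(=O)Nc3ccc(S(N)(=O)=O)cc3)cc12` is not yet measured. Its change from compound 3 is 2-methoxyphenyl in place of 3-chloro-2-fluorophenyl on a nitrogen on an aromatic ring. The measured steps bear on it only loosely, since every one of them swaps one halogenated aryl for another; none introduces a methoxy-bearing aryl. Those steps were modest, so a step of similar size is expected here, most likely upward, because compound 3 already holds the lowest number at 6930 nM and each change away from it has so far cost potency. The expected step is a 2.9-fold higher number from compound 3 to compound 4 (0.46 log units; beyond the scatter). Compound 4 is therefore estimated at 20000 nM, with a range from 6000 nM to 60000 nM.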

Compound 4, half-maximal inhibitory concentration: 8030 nM
Beside the measured number, compound 4's estimate is 2.5-fold (0.40 log units) above it, and the stated range covers the measured number.
By their numbers in this assay, from the lowest: compounds 3 and 4 (each within the scatter of the next); then compounds 1 and 2 (each within the scatter of the next).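

In this assay, this position on the nitrogen tolerates an aryl group with no halogen at all: replacing 3-chloro-2-fluorophenyl with 2-methoxyphenyl gives a 1.2-fold higher number from compound 3 to compound 4 (0.06 log units; within the scatter). The bottom of this small series is therefore not held by a halogenated aryl alone, and the 2-methoxyphenyl group also separates clearly from both bromine-bearing aryl groups, with a 3.9-fold lower number from compound 2 to compound 4 (0.59 log units; beyond the scatter) and a 2.9-fold lower number from compound 1 to compound 4 (0.46 log units; beyond the scatter). Nothing available here explains why these aryl groups rank as they do.

On these data alone, it remains open whether a plain phenyl or a 2-methylphenyl on this nitrogen would fall in the same range as the 2-methoxyphenyl group. As far as these compounds go, all four compounds also keep the rest of the molecule fixed, so the effect of a shorter chain or of a carboxylic acid in place of the sulfonamide is unknown.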